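The source may hold more compounds than are shown below. What is called first, only, known or untested is meant among the compounds shown, and "the series" means these compounds.

Measured compounds:
Compound 1 `CCOCCOC(=O)Nc1cc2nc(C3CCCCC3)[nH]c2cc1N(C)C`: in an ADME assay on Vero cells (Chlorocebus sabaeus) for cytotoxicity, read by resazurin assay, with a stated time of 3 days (a lower number here means a stronger inhibitor, a higher number a weaker inhibitor), compound 1 gives > 100 ug/mL, a limit of the assay.
Compound 2 `CN(C)c1cc2[nH]c(C3CCCCC3)nc2cc1NC(=O)OCC(F)(F)F`: in this assay compound 2 gives > 100 ug/mL, likewise a limit.

Compound 2 thus sits at the limit, as do all values shown (the limit of > 100 ug/mL in this assay, at which 2 of the 2 values shown sit). For the measured compounds named here, the one measured step, a step that the two limits leave unreadable from compound 1 to compound 2, is unreadable. Compound 3 `CCCCOC(=O)Nc1cc2nc(C3CCCCC3)[nH]c2cc1N(C)C` differs from compound 2 by propyl in place of trifluoromethyl on a saturated chain carbon bound to an oxygen next to a carbonyl group. No measured step bears on this change, and the single step shown gives no size to go by. In this assay compound 3 is expected to remain at the limit, with the step that the limit leaves unreadable from compound 2 to compound 3 estimated as none beyond the scatter. The estimate for compound 3 is 150 ug/mL, expected between 60 ug/mL and 400 ug/mL.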

Compound 3, half-maximal inhibitory concentration: > 100 ug/mL
Compound 3 ended at the assay's limit; the forecaster's own chance of this, stated with the estimate: 85%; the middle value is on the limit's open side.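

In this assay compound 1, compound 2 and compound 3 all stand at the limit of the assay, and no new step can be read among them. On these data alone, how far each lies beyond that limit remains open, as does whether any change in the chain shifts this read-out.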